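Chlorine added to a benzylpurine core, second isomer

The compounds below may be only part of what the source reports. "The series", "measured", "known", "first", "only" and "open" are said of these compounds alone.

Of the compounds shown here, three have been tested in a functional assay on T47D cells (Homo sapiens) for cytotoxicity, read by sulforhodamine B assay, with a stated time of 48 h; on this read-out higher numbers stand for weaker inhibition of growth and lower numbers for stronger inhibition of growth. Compound 1 `ClCc1ccccc1Cn1cnc2c(Cl)nc(Cl)nc21` gives 1990 nM in this assay. Compound 2 `ClCc1ccccc1Cn1cnc2c(Cl)ncnc21` gives 17800 nM in this assay. Compound 3 `ClCc1ccccc1Cn1cnc2ncnc(Cl)c21` gives 1990 nM in this assay, level with compound 1 at the digits printed; the two together sit lowest of the three numbers, and compound 2 stands furthest from compound 3. The difference between the core of compound 3 and the core of compound 2 is not broken down here.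

One structural change appears twice in this set. From compound 2 to compound 1 it is chloro in place of hydrogen on an aromatic carbon, and the step was an 8.9-fold lower number from compound 2 to compound 1 (0.95 log units; beyond the scatter). The fourth compound, compound 4 `ClCc1ccccc1Cn1cnc2nc(Cl)nc(Cl)c21`, has not yet been measured. It differs from compound 3 by chloro in place of hydrogen on an aromatic carbon, the same change at the same kind of place, on a different core.

Compound 4 is expected to give a lower number than compound 3 in this assay, because the earlier step of an 8.9-fold lower number from compound 2 to compound 1 (0.95 log units; beyond the scatter) went the same way; yet compound 3 already stands where compound 1 stands, so a smaller step is estimated, a 3.3-fold lower number from compound 3 to compound 4 (0.52 log units; beyond the scatter). For compound 4 the estimate is 600 nM in this assay, with a range from 150 nM to 2500 nM.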

Compound 4, concentration for 50% growth inhibition: 580 nM
Beside the measured number, compound 4's estimate is 1.0-fold (0.01 log units) above it; measured number inside the range.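

In this assay, chloro in place of hydrogen on an aromatic carbon lowered the number again on the second core, with a 3.4-fold lower number from compound 3 to compound 4 (0.54 log units; beyond the scatter), so the change went the same way on both cores shown. Set side by side, the two steps cannot be told apart in size: the same change on two cores in this assay, an 8.9-fold lower number (0.95 log units; beyond the scatter) from compound 2 to compound 1 and a 3.4-fold lower number (0.54 log units; beyond the scatter) from compound 3 to compound 4, 2.6-fold (0.42 log units) apart, within the scatter of two such steps. Among the compounds shown here, this shows that the direction of the change carried from one core to the other and that its size held within the scatter, but it rests on only one pair of compounds per core, so it does not show that the change would behave alike on any further core, nor why it lowers the number.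

The compounds shown leave open whether another group on the aromatic carbon between two ring nitrogen atoms, such as an amine or a methoxy group, would give a step of like direction and size on these cores. They also leave open how much the chloromethyl group shared by all four compounds contributes to these numbers, for instance whether a methyl or a hydroxymethyl group in its place would preserve them.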